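This account rests on a few compounds, and the source may have more. Where it says the series, first, only, none or still open, it means among the compounds named here.

In an ADME assay on microsomes from liver (Homo sapiens) for metabolic stability, read by LC-MS, tested at 1 uM (a higher number here means faster removal of the compound, a lower number slower removal), the shared core appears in three measured compounds. Compound 2 `NCCOCCOc1ccc([C@H]2CC[C@]3(CC2)OOC2(O3)C3CC4CC(C3)CC2C4)cc1` gives < 7 mL.min-1.g-1 in this assay, a value that is a limit of the assay rather than a number. Compound 1 `N[C@H]1CC[C@@H](Oc2ccc([C@H]3CC[C@]4(CC3)OOC3(O4)C4CC5CC(C4)CC3C5)cc2)CC1` likewise gives only a limit of this assay, < 7 mL.min-1.g-1. Compound 3 `CS(=O)(=O)N1CCN(CCCOc2ccc([C@H]3CC[C@]4(CC3)OOC3(O4)C4CC5CC(C4)CC3C5)cc2)CC1`, by contrast, gives 68 mL.min-1.g-1 in this assay. The step that the two limits leave unreadable from compound 1 to compound 2 therefore cannot be sized, whereas the step of an at least 9.7-fold higher number from compound 2 to compound 3 (0.98 log units; beyond the scatter) is plain.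

The unmeasured compound 4 `N[C@H]1CC[C@H](Oc2ccc([C@H]3CC[C@]4(CC3)OOC3(O4)C4CC5CC(C4)CC3C5)cc2)CC1` differs from compound 2 as follows: 4-aminocyclohexyl in place of 2-(2-aminoethoxy)ethyl on an oxygen on an aromatic ring. The same kind of exchange, run in the other direction, is the step from compound 1 to compound 2, and both of those compounds sit at the limit of < 7 mL.min-1.g-1 in this assay, at which 2 of the 3 values shown sit. Compound 1 carries the same 4-aminocyclohexyl group, differing only in its stereocentres, and stays at that limit. On that basis compound 4 is expected to show a change of a step that the limit leaves unreadable from compound 2 to compound 4 in this assay and to remain near the limit. Compound 4 is thus estimated at 5 mL.min-1.g-1 in this assay, with a range from 2 mL.min-1.g-1 to 12 mL.min-1.g-1.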

Compound 4, intrinsic clearance in microsomes: < 7 mL.min-1.g-1
Compound 4: only a limit was reported; the forecaster's own chance of this, stated with the estimate: 70%; the middle value does not contradict the limit.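

Compound 4 stands with compounds 1 and 2 at a limit of the assay rather than at a number, and no step to compound 4 from either of them can be read: the limit of < 7 mL.min-1.g-1 in this assay, at which 3 of the 4 values shown sit.

As far as these compounds go, whether compounds 1, 2 and 4 differ at all in this assay remains open.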